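The compounds below may be only part of what the source reports. "The series", "measured", "known", "first", "only" and "open" are said of these compounds alone.

Measured in a functional assay on MDA-MB-231 cells (Homo sapiens) for inhibition, read by MTT assay, with a stated time of 72 h; a higher number here means a weaker inhibitor, a lower number a stronger inhibitor:
- Compound 1 `Cc1ccccc1-c1cc(C(=O)N2CCC3(CC2)CC(=O)c2nn(C(C)(C)C)cc2O3)c2ccccc2n1`: > 10000 nM
- Compound 2 `CC(C)(C)n1cc2c(n1)C(=O)CC1(CCN(C(=O)c3cc(-c4ccc(Br)cc4)nc4ccccc34)CC1)O2`: > 10000 nM
- Compound 3 `COc1ccc(-c2cc(C(=O)N3CCC4(CC3)CC(=O)c3nn(C(C)(C)C)cc3O4)c3ccccc3n2)cc1`: > 10000 nM

Compound 2 has no exact number, only a limit, > 10000 nM. Among the compounds with values here, it is not alone in this, as the series so far shows (the limit of > 10000 nM in this assay, at which 3 of the 3 values shown sit).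

Compound 4 `CC(C)(C)n1cc2c(n1)C(=O)CC1(CCN(C(=O)c3cc(N4CCNCC4)nc4ccccc34)CC1)O2` keeps the core of compound 2 and changes one group, with piperazin-1-yl in place of 4-bromophenyl on an aromatic carbon, next to the ring nitrogen: piperazin-1-yl in place of 4-bromophenyl on an aromatic carbon.

Within the data shown here, three measured steps bear on this change. Among the measured compounds shown here, the first is a step that the two limits leave unreadable from compound 1 to compound 2, the second is a step that the two limits leave unreadable from compound 1 to compound 3, and the third is a step that the two limits leave unreadable from compound 2 to compound 3. None of them has a readable size, so none gives a size or direction to carry over. All three compounds also keep a six-membered aromatic ring of carbon only at this place, which compound 4 does not, so they are a thin guide to the new group.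

No clear step is therefore expected in this assay, and the estimate stands as a step that the limit leaves unreadable from compound 2 to compound 4. Compound 4 is most likely to meet the same limit as the others. If a number is reported, the expected value for compound 4 is 12000 nM, with an estimated range of 3000 nM to 40000 nM.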

Compound 4, half-maximal inhibitory concentration: 4200 nM
For compound 4 the middle estimate is 2.9-fold (0.46 log units) above the measured one; low and high end bracket the measured number.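

Within the data shown here, with piperazin-1-yl on the aromatic carbon next to the ring nitrogen, compound 4 gives the first exact number in this assay, which shows that the group at this position can move the read-out past the limit. Putting piperazin-1-yl in place of each of the earlier groups gives an at least 2.3-fold lower number from compound 2 to compound 4 (0.37 log units; beyond the scatter), then an at least 2.3-fold lower number from compound 3 to compound 4 (0.37 log units; beyond the scatter), and an at least 2.3-fold lower number from compound 1 to compound 4 (0.37 log units; beyond the scatter), and each of these sizes is only a minimum, set by a limit on one side. Compound 1, compound 2 and compound 3, which all keep a six-membered aromatic ring of carbon only at this place, give no readable steps among themselves, and their values are limits and not numbers: the limit of > 10000 nM in this assay, at which 3 of the 4 values shown sit.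

With only one non-aromatic group shown at this position, the compounds leave open whether the step goes with losing the six-membered aromatic ring of carbon only or with piperazin-1-yl itself, a question that morpholin-4-yl or piperidin-1-yl would help to settle. Also open, from the compounds shown here alone, is whether 4-methylpiperazin-1-yl, or a longer chain on the outer piperazine nitrogen, would shift the number of compound 4 from its 4200 nM.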